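This account rests on a few compounds, and the source may have more. Where it says the series, first, only, none or still open, it means among the compounds named here.

Compounds measured:
compound 1, `Cc1nn(-c2ccccc2)c2nc(O)c(-c3nc(N)cc(N)n3)cc12` — in a functional assay on aorta (Rattus norvegicus, strain Sprague-Dawley) (a lower number here means that less compound is needed, a higher number that more compound is needed for the effect), compound 1 gives "not determined" (no result reported)
compound 2, `Cc1nn(-c2ccccc2)c2nc(OCc3ccccc3F)c(-c3nc(N)cc(N)n3)cc12` — 2200 nM

In this assay compound 2 gives 2200 nM. This is the only number shown; compound 1 is the one further entry without a single number, so compound 2 stands alone and no comparison between measured compounds is possible. Compound 3, `Cc1nn(-c2ccccc2)c2nc(OCc3ccccc3F)c(-c3nc(N)c(N4CCCCC4)c(N)n3)cc12`, is still to be measured in this assay. It differs from compound 2 in one place: piperidin-1-yl in place of hydrogen on an aromatic carbon. Here piperidin-1-yl enters where a hydrogen leaves, on an aromatic carbon ortho to two amino groups and para to a large group. Among the measured compounds shown here, with no step between measured compounds to lean on, the direction cannot be read from the data; the writer expects a step in this assay no larger than the scatter, leaning slightly toward less compound being needed, a 1.5-fold lower number from compound 2 to compound 3 (0.17 log units; within the scatter). For compound 3 the expected value in this assay is 1500 nM, within a range from 400 nM to 6000 nM.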

Compound 3, half-maximal effective concentration: 790 nM
Compound 3: middle estimate off by 1.9-fold (0.28 log units), on the high side; the measured number falls inside the stated range.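

In this assay the aromatic carbon ortho to two amino groups accepts a substituent without loss: piperidin-1-yl in place of hydrogen gives a 2.8-fold lower number from compound 2 to compound 3 (0.44 log units; beyond the scatter), a modest move toward less compound being needed. Among the compounds shown here, until now nothing could be said about this position, as compound 2 stood alone and compound 1 offered no number, so this is the first sign that a six-membered non-aromatic ring can sit here and that the read-out responds to the change. Nothing shown here explains the step.

The compounds shown leave open whether the shift belongs to the ring as a whole or to any amine on this carbon. A dimethylamino group or a morpholin-4-yl ring at the same place would separate these two readings.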